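From formyl to methoxy: expecting a loss of inhibition

The compounds below may be only part of what the source reports. "The series", "measured", "known", "first", "only" and "open" are said of these compounds alone.

The two measured compounds, both tested in an assay on isolated protein for inhibition of Rho-associated protein kinase 1 (Homo sapiens), read by scintillation counting, radiometric assay and 33P incorporation, with a stated time of 40 min, in the presence of a further agent that is not named here; on this read-out lower numbers stand for stronger inhibition and higher numbers for weaker inhibition:
Compound 1 `COc1cccc(OCC(=O)Nc2cccc(NC(=O)c3ccc(N(C)C)cc3)c2)c1` gives only a limit in this assay, > 10000 nM.
Compound 2 `COc1cc(OCC(=O)Nc2cccc(NC(=O)c3ccc(N(C)C)cc3)c2)ccc1C=O` gives 3740 nM in this assay.

Among the measured compounds shown here, compound 2 is the only one of the pair with a number in this assay; compound 1 sits at the limit (the limit of > 10000 nM in this assay, at which 1 of the 2 values shown sits). For the measured compounds named here, the single measured step, an at least 2.6-fold lower number from compound 1 to compound 2 (0.42 log units; beyond the scatter), is therefore known only as a bound on its size, and it is the one piece of evidence bearing on compound 3.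

Compound 3 `COc1ccc(OCC(=O)Nc2cccc(NC(=O)c3ccc(N(C)C)cc3)c2)cc1OC` differs from compound 2 by methoxy in place of formyl on an aromatic carbon. The formyl group that arrived in the step from compound 1 to compound 2 leaves again; in its place stands a methoxy group, not the hydrogen of compound 1, so the measured step does not describe the change exactly. The expectation is that compound 3 gives a higher number than compound 2 in this assay, with the step of a 2.1-fold higher number from compound 2 to compound 3 (0.33 log units; beyond the scatter) estimated as roughly the size of the measured step run backward. The estimate for compound 3 in this assay is 8000 nM, within a range from 2500 nM to 30000 nM.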

Compound 3, half-maximal inhibitory concentration: > 10000 nM
Compound 3 gave a limit, no number; the forecaster's own chance of this, stated with the estimate: 40%; middle value at least 1.2-fold (0.09 log units) from the limit.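

Methoxy in place of formyl on this aromatic carbon, ortho to a methoxy group and para to a large group, gives an at least 2.6-fold higher number from compound 2 to compound 3 (0.42 log units; beyond the scatter) in this assay, so exchanging formyl for a group with the same count of heavy atoms and of hydrogen-bond acceptors does not keep the measurable inhibition. Among the compounds shown here, the earlier pair showed only that formyl gave a number where hydrogen did not; it is now also the only one of the three groups seen at this place to give a number, and the gain does not extend to methoxy. The step between the two compounds that sit at the limit cannot be read, so hydrogen and methoxy at this place cannot be put in order, and the series rests on a single number: the limit of > 10000 nM in this assay, at which 2 of the 3 values shown sit.

From the compounds shown here alone, what a carboxylic acid, an aminomethyl group or a nitrile on this aromatic carbon would give in this assay remains open. Also open, going by these compounds, is how much weaker than the limit the true values of the two limited compounds lie, and so how large the full effect of formyl is.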